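Cyclopropane amides in the biphenyl series: heteroaryl replacement

The compounds below may be only part of what the source reports. "The series", "measured", "known", "first", "only" and "open" are said of these compounds alone.

Measured so far:
compound 1 `CC(C)C[C@H](N)CN(C(=O)C(C)Cc1ccccc1)c1ccc(-c2ccccc2)cc1` — 1.2 nM
compound 2 `CC[C@@H](C)[C@H](N)CN(C(=O)[C@@H]1C[C@H]1c1ccccc1)c1ccc(-c2ccccc2)cc1` — 1.4 nM
compound 3 `CC[C@H](C)[C@H](N)CN(C(=O)[C@@H]1C[C@H]1c1cc(F)cc(F)c1)c1ccc(-c2ccccc2)cc1` — 960 nM

In a functional assay for agonist activity at G protein-coupled receptor 88 (Homo sapiens), read by HTRF and cAMP accumulation (a lower number here means that less compound is needed, a higher number that more compound is needed for the effect), compound 3 gives 960 nM, the highest number of the three. Compound 2 gives 1.4 nM and compound 1 gives 1.2 nM in this assay, both far lower than compound 3, beyond the scatter in each case. Among the measured compounds shown here, no pair of these differs in only one place, so no single step can be read from them.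

Compound 4 `CC[C@H](C)[C@H](N)CN(C(=O)[C@@H]1C[C@H]1c1nc(C)c(C)s1)c1ccc(-c2ccccc2)cc1` keeps the core and the cyclopropane of compound 3 and changes one group: 4,5-dimethyl-1,3-thiazol-2-yl in place of 3,5-difluorophenyl on a saturated ring carbon. For the measured compounds named here, no measured pair shows this exchange, so the data give no direction for it. The step from compound 3 to compound 4 in this assay is expected to be small, a 1.6-fold lower number from compound 3 to compound 4 (0.20 log units; within the scatter), not clearly beyond the scatter in either direction. Compound 4 is therefore estimated at 600 nM in this assay, with a range from 100 nM to 4000 nM, the width reflecting the absence of any comparable exchange among the measured compounds.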

Compound 4, half-maximal effective concentration: 3600 nM
Estimate against measurement, compound 4: 6.0-fold (0.78 log units) below, within the range that was stated.
By their numbers in this assay, from the lowest: compounds 1 and 2 (each within the scatter of the next); then compound 3; then compound 4.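

In this assay, among the compounds shown here, 4,5-dimethyl-1,3-thiazol-2-yl in place of 3,5-difluorophenyl on a saturated ring carbon gives a 3.8-fold higher number from compound 3 to compound 4 (0.57 log units; beyond the scatter), the only single-place step available so far. The position is therefore sensitive to the group it carries, and this heteroaryl replacement, with its five-membered aromatic ring and two hydrogen-bond acceptors, does not bring the number down from the high value of compound 3. Nothing available accounts for the direction or size of this step.

Open, going by these compounds, is whether the step follows from the ring itself or from its two methyl groups, which a 1,3-thiazol-2-yl without methyl groups or a pyridyl ring would help separate. Also open, on these data alone, is whether the same exchange gives a step of similar size with a different stereochemistry in the amine side chain.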